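Turning one ring stereocentre in a weak inhibitor

The source may report more compounds than this note shows. Statements on the series, on what has been measured and on what is new or still open speak of the compounds shown alone.

Compound 1 `O=C1/C(=C2/C(=O)N([C@@H]3O[C@H](CO)[C@@H](O)[C@H](O)[C@H]3O)c3ccccc32)Nc2ccccc21`: 14400 nM
Compound 2 `C[C@@H]1O[C@@H](N2C(=O)/C(=C3\Nc4ccccc4C3=O)c3ccccc32)[C@H](O)[C@H](O)[C@H]1O`: > 25000 nM

Two measured compounds are shown, both tested in a functional assay on 5637 cells (Homo sapiens) for antiproliferative activity, read by crystal violet staining, with a stated time of 96 h; on this read-out higher numbers stand for weaker inhibition and lower numbers for stronger inhibition. Compound 1 gives 14400 nM in this assay. For compound 2 the read-out is a limit and not a number: it stands at the limit of > 25000 nM in this assay, at which 1 of the 2 values shown sits, so all that is known is that compound 2 inhibits the cells more weakly than that boundary can show.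

Compound 3 `C[C@@H]1O[C@H](N2C(=O)/C(=C3\Nc4ccccc4C3=O)c3ccccc32)[C@H](O)[C@H](O)[C@H]1O` is not yet measured. Set against compound 2 it changes in one place: the two compounds have the same atoms and bonds and differ only in configuration as drawn: 1 of 6 stereo elements differ; a stereocentre at a saturated ring carbon is drawn R in compound 2 and S in compound 3. No step between two measured compounds is shown, so nothing here tells how large a change of configuration at that carbon can move the numbers in this assay.

With compound 2 sitting at the limit, compound 3 is expected to stay in the same weak region, and the step from compound 2 to compound 3 is estimated as an at least 1.2-fold lower number from compound 2 to compound 3 (0.09 log units; that floor lies within the scatter). Compound 3 is expected to give about 20000 nM in this assay, within a range from 8000 nM to 40000 nM, with a fair chance that only a limit is reported again.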

Compound 3, half-maximal inhibitory concentration: > 12500 nM
Compound 3 was reported as a limit; the forecaster's own chance of this, stated with the estimate: 50%; the middle value lies beyond the limit too.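

Compound 2 and compound 3 are both reported only as limits in this assay, so no step can be read between them. Compound 2 has the limit > 25000 nM. Compound 3 has the limit > 12500 nM. The compounds shown leave open how far, if at all, turning this one ring stereocentre moves the read-out.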